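A larger group where a chloro stood on compound 3

The source may hold more compounds than are shown below. What is called first, only, known or untested is meant among the compounds shown, and "the series" means these compounds.

Compound 3 `O=C(CCCCCCc1ccccc1)c1ncc(Cl)o1` is a ketone whose carbonyl carbon carries a 5-chloro-1,3-oxazol-2-yl group. In an assay on HEK-293T cells for inhibition of diacylglycerol lipase-alpha (Homo sapiens), read by colorimetric assay (a higher number here means a weaker inhibitor, a lower number a stronger inhibitor), compound 3 gives > 10000 nM, which is a limit of the assay and not a number. Compound 1 `O=C(CCCCCCc1ccccc1)c1nncs1` gives > 10000 nM in this assay, also a limit. Compound 2 `Cn1nnc(C(=O)CCCCCCc2ccccc2)n1` gives > 10000 nM, a limit as well. All three values sit at the limit of > 10000 nM in this assay, at which 3 of the 3 values shown sit, and the steps a step that the two limits leave unreadable from compound 1 to compound 2, a step that the two limits leave unreadable from compound 1 to compound 3 and a step that the two limits leave unreadable from compound 2 to compound 3 are therefore unreadable. Compound 4 `O=C(CCCCCCc1ccccc1)c1ncc(-c2ccc(F)cc2)o1` differs from compound 3 by 4-fluorophenyl in place of chloro on an aromatic carbon. Among the compounds with values here, no measured step involves such a change, so its size and direction are unknown. With nothing to lean on, compound 4 is expected to remain near the limit, at an estimated 8000 nM in this assay, between 1500 nM and 40000 nM. That would be an estimated step of an at least 1.2-fold lower number from compound 3 to compound 4 (0.09 log units; that floor lies within the scatter).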

Compound 4, half-maximal inhibitory concentration: > 10000 nM
Compound 4 gave a limit, no number (the forecaster's own chance of this, stated with the estimate: 60%); at least 1.2-fold (0.09 log units) between middle value and limit.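

The step from compound 3 to compound 4 cannot be read, since both compounds give only a limit and no number: the limit of > 10000 nM in this assay, at which 4 of the 4 values shown sit.

The compounds shown leave open which change to the shared core, if any, would give a readable number in this assay.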